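The compounds below may be only part of what the source reports. "The series", "measured", "known", "first", "only" and "open" are said of these compounds alone.

Measured compounds in an ADME assay on MT4 cells (Homo sapiens) for cytotoxicity, read by MTT assay; on this read-out higher numbers stand for lower toxicity in this test and lower numbers for higher toxicity in this test:

compound 1, `N#Cc1ccc(NC(=S)OCCc2ccccn2)cc1`: 45000 nM
compound 2, `Fc1ccc(NC(=S)OCCc2ccccn2)cc1`: only a limit, > 100000 nM

Compound 2 gives no number in this assay; its value is a limit, > 100000 nM. Among the compounds with values here, the one measured step, an at least 2.2-fold higher number from compound 1 to compound 2 (0.34 log units; beyond the scatter), sits at the limit of > 100000 nM in this assay, at which 1 of the 2 values shown sits, so its true size is unknown beyond the stated minimum.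

Next step: compound 3, `COc1ccc(NC(=S)OCCc2ccccn2)cc1`, differs from compound 2 by methoxy in place of fluoro on an aromatic carbon. Within the data shown here, no measured step bears directly on this exchange; the only step in hand, from compound 1 to compound 2, concerns the fluoro entering and points to low toxicity for compound 2. Against that background, compound 3 is expected to stay near the same region, with a step of a number no higher from compound 2 to compound 3 (the limit leaves the size open) expected in this assay. Compound 3 is therefore estimated at 100000 nM, within 40000 nM to 250000 nM, with a fair chance that only a limit is reported again.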

Compound 3, half-maximal cytotoxic concentration: 48000 nM
Compound 3: the middle estimate sits 2.1-fold (0.32 log units) above what was measured; low and high end bracket the measured number.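

In this assay, methoxy in place of fluoro on this aromatic carbon, para to a large group, gives an at least 2.0-fold lower number from compound 2 to compound 3 (0.31 log units; beyond the scatter), so the high number seen with fluoro does not extend to every group at this place. The value of compound 2 is only a limit, and the step to compound 3 is therefore a minimum: the limit of > 100000 nM in this assay, at which 1 of the 3 values shown sits.

Methoxy and cyano read alike here, with a 1.1-fold higher number from compound 1 to compound 3 (0.03 log units; within the scatter), which leaves fluoro as the one group of the three that stands apart, towards lower toxicity in this test.

Still open, as far as these compounds go, is whether that reading belongs to fluoro alone or is shared by chloro or a plain hydrogen at this carbon. Also open, from the compounds shown here alone, is how an amine or a longer alkoxy chain at the same place would read in this assay.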